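This account rests on a few compounds, and the source may have more. Where it says the series, first, only, none or still open, it means among the compounds named here.

Compound 1 `CC1(C)CCC(C)(C)c2cc(C(=O)c3ccc(/C=C/C(=O)O)cc3)ccc21` reaches 78% in a functional assay for activation of retinoic acid receptor beta (Homo sapiens); on this read-out lower numbers stand for smaller maximal responses and higher numbers for larger maximal responses. Within the data shown here, compound 2 `C/C(=C\C(=O)O)c1ccc(C(=O)c2ccc3c(c2)C(C)(C)CCC3(C)C)cc1` reaches 47% in this assay, which is a number 31 percentage points lower from compound 1 to compound 2 (beyond the scatter) and leaves compound 2 with the lower of the two numbers measured so far. Compound 3 `C/C(=C\c1ccc(C(=O)c2ccc3c(c2)C(C)(C)CCC3(C)C)cc1)C(=O)O` differs from compound 2 by 2-carboxyprop-1-en-1-yl in place of 2-carboxy-1-methylethenyl on an aromatic carbon. Among the measured compounds shown here, the only step that bears on this is a number 31 percentage points lower from compound 1 to compound 2 (beyond the scatter), where moving one methyl changed the response strongly, so a further shift of that methyl is expected to move the number again, though its direction is uncertain; the estimate for compound 3 is a step of a number 13 percentage points higher from compound 2 to compound 3 (beyond the scatter), giving an expected 60% with a range from 35% to 85%.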

Compound 3, largest response reached (reported as maximum), in percent of the reference or control that the assay uses: 70%
Beside the measured number, compound 3's estimate is 10 percentage points below it; the range from low to high includes it.
By their numbers in this assay, from the lowest: compound 2; then compounds 3 and 1 (each within the scatter of the next).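

With the same atoms and only the methyl placed differently on the chain, this assay shows a number 23 percentage points higher from compound 2 to compound 3 (beyond the scatter). The response at this position therefore depends on where the methyl sits on the chain, and not merely on whether one is there. 2-carboxyprop-1-en-1-yl in place of 2-carboxyethenyl gives a number 8 percentage points lower from compound 1 to compound 3 (within the scatter), so a methyl on this chain need not cost response, though nothing available here explains the difference between the two placements. Going by these compounds, whether an ethyl in place of that methyl, or an amide in place of the carboxylic acid, would hold the response remains open.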